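Trading a cyanoamino group for a ureido group

The source may hold more compounds than are shown below. What is called first, only, known or untested is meant among the compounds shown, and "the series" means these compounds.

Of the compounds shown here, three sharing one core have been measured in a functional assay on the whole organism for inhibition, with Rattus norvegicus as the target, with stated times of 1 h and 3.5 h, at a dose of 100 mg/kg by the oral route; a higher number here means more inhibition at the dose given (going by the name of the read-out), a lower number less inhibition. Compound 1 `Cc1ncc(-c2ccccc2)c(C(C)(C)C)n1`, which carries a methyl group on its core, gives 22% in this assay. Compound 2 `CC(C)(C)c1nc(-c2ccccc2)ncc1-c1ccccc1` puts a phenyl group in that place; in this assay compound 2 gives only a limit of the assay, < 5%. Compound 3 `CC(C)(C)c1nc(NC#N)ncc1-c1ccccc1` carries a cyanoamino group there instead; in this assay compound 3 likewise gives only a limit, < 5%. The steps read a number at least 17 percentage points lower from compound 1 to compound 2 (beyond the scatter) and a number at least 17 percentage points lower from compound 1 to compound 3 (beyond the scatter), while a step that the two limits leave unreadable from compound 2 to compound 3. What is known of compound 3 is thus only that it sits at the floor of the measurement, because of the limit of < 5% in this assay, at which 2 of the 3 values shown sit.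

The next compound, compound 4 `CC(C)(C)c1nc(NC(N)=O)ncc1-c1ccccc1`, keeps the cyanoamino nitrogen of compound 3 and alters what hangs on it: carbamoyl in place of cyano on a nitrogen on an aromatic ring. Within the data shown here, no measured step swaps one group for another on this nitrogen, so only the step ending at compound 3 bears on it, and it shows compound 3 already low in this assay. A small step is therefore expected, a number at least 3 percentage points higher from compound 3 to compound 4 (that floor lies within the scatter), with a fair chance that a limit is again reported. Compound 4 is estimated at 8% in this assay, within the range 0% to 25%.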

Compound 4, a percentage reported as inhibition, in the whole organism at one dose (the size of the read-out at that dose, not a potency): 14%
Compound 4: the middle estimate sits 6 percentage points below what was measured; the range from low to high includes it.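

Carbamoyl in place of cyano on this nitrogen, the change from cyanoamino to ureido, gives a number at least 9 percentage points higher from compound 3 to compound 4 (that floor lies within the scatter) in this assay and so yields a measured number where cyanoamino gave only a limit. Set against phenyl at the same place on the core, ureido reads a number at least 9 percentage points higher from compound 2 to compound 4 (that floor lies within the scatter) and set against methyl it reads a number 8 percentage points lower from compound 1 to compound 4 (within the scatter) so methyl and ureido cannot be told apart here, while phenyl and cyanoamino each lie beyond the scatter from compound 1. Going by these compounds, the true size of the two steps up from compound 2 and compound 3 stays unknown because each begins at a limit: the limit of < 5% in this assay, at which 2 of the 4 values shown sit.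

The compounds shown leave open whether other groups on this nitrogen would behave as carbamoyl does, such as a plain amine, an acetyl group or a longer chain on the ureido group. They also leave open how a carboxylic acid at this place would compare with methyl, and whether any group here can rise beyond the scatter from compound 1 in this assay at all.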